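This account rests on a few compounds, and the source may have more. Where it says the series, first, only, none or still open, it means among the compounds named here.

Measured in a functional assay on SK-MEL-28 cells (Homo sapiens) for inhibition, read by MTT assay, with a stated time of 48 h; on this read-out higher numbers stand for weaker inhibition and lower numbers for stronger inhibition:
Compound 1 `CCc1ccc(-c2nc3ccccn3c2Sc2ccccc2)cc1`: > 100000 nM
Compound 2 `c1ccc(Sc2c(-c3cccc4ccccc34)nc3ccccn23)cc1`: > 100000 nM

In this assay compound 1 gives > 100000 nM, and this is a limit of the assay, not a number. Compound 2 gives > 100000 nM, which is also a limit. The record so far is therefore (the limit of > 100000 nM in this assay, at which 2 of the 2 values shown sit).

Compound 3 `CSc1ccc(-c2nc3ccccn3c2Sc2ccccc2)cc1` has not yet been measured. It keeps the core of compound 1 and changes a single group: methylsulfanyl in place of ethyl on an aromatic carbon. In words, methylsulfanyl takes the place of ethyl on an aromatic carbon, para to a large group.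

Among the measured compounds shown here, no measured pair shows what a change at this place does, and neither measured compound offers an exact number as a starting point. The expectation is thus a cautious one: no step beyond the usual scatter, with any real shift more likely toward stronger inhibition. The estimated change is a number no higher from compound 1 to compound 3 (the limit leaves the size open). For compound 3 the expected value is 100000 nM, with an estimated range from 25000 nM to 200000 nM.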

Compound 3, half-maximal inhibitory concentration: 67700 nM
Compound 3: middle estimate off by 1.5-fold (0.17 log units), on the high side; measured number inside the range.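

In this assay, among the compounds shown here, compound 3 gives 67700 nM as the first exact number in this set, so a compound carrying 4-(methylsulfanyl)phenyl in place of 4-ethylphenyl can give a reading inside the range of the assay. Compound 1 gives > 100000 nM as its reading, and this is a limit of the assay, not a number. Going by these compounds, the change from ethyl to methylsulfanyl on this aromatic carbon can thus be read only as a floor, an at least 1.4-fold lower number from compound 1 to compound 3 (0.16 log units; that floor lies within the scatter), so the true size of the step remains unknown and the floor alone does not establish a real gain in inhibition.

On these data alone, whether an amine, a carboxylic acid or a longer chain at this same place would lower the number further, or raise it again, remains open. Little can be ranked yet, because the record still rests largely on a single reading: the limit of > 100000 nM in this assay, at which 2 of the 3 values shown sit.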